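This account rests on a few compounds, and the source may have more. Where it says the series, first, only, none or still open, it means among the compounds named here.

Within the data shown here, compound 2 `O=c1c(-c2nn[nH]n2)c[nH]c2c(Cl)cccc12` gives the only plain number on hand in a functional assay on the whole organism (strain Sprague-Dawley) for inhibition, with Rattus norvegicus as the target (on this read-out lower numbers stand for an effect already at smaller amounts and higher numbers for an effect only at larger amounts of compound), namely 0.078 mg/kg. Compound 1 `COc1ccc2c(O)c(C(=O)O)cnc2c1` reaches only a limit of the assay, > 50 mg/kg. Compound 3 `O=c1c(-c2nn[nH]n2)c[nH]c2c(Cl)ccc(Cl)c12` likewise stops at a limit, > 0.156 mg/kg. Among the measured compounds shown here, the single measured step, an at least 2.0-fold higher number from compound 2 to compound 3 (0.30 log units; that floor lies within the scatter), is chloro in place of hydrogen on an aromatic carbon. Compound 4 `CCc1cccc2c(=O)c(-c3nn[nH]n3)c[nH]c12` differs from compound 2 by ethyl in place of chloro on an aromatic carbon. For the measured compounds named here, no measured step swaps one substituent for another on that carbon, so the chloro-for-hydrogen step is only a weak guide; exchanging chloro for ethyl is expected to give a 1.3-fold higher number from compound 2 to compound 4 (0.11 log units; within the scatter), within the scatter. Compound 4 is therefore estimated at 0.1 mg/kg, with a range from 0.03 mg/kg to 0.4 mg/kg.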

Compound 4, minimum effective dose: 0.312 mg/kg
Compound 4: the middle estimate sits 3.1-fold (0.49 log units) below what was measured; the measured number falls inside the stated range.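

In this assay, this carbon now has a direct exchange of one substituent for another: ethyl in place of chloro gives a 4.0-fold higher number from compound 2 to compound 4 (0.60 log units; beyond the scatter). This is the only step shown that is clearly beyond the scatter, so the read-out depends on which group sits at this carbon, and chloro and ethyl are not interchangeable there. Nothing on hand gives a cause for this step. Still open, on these data alone, is how hydrogen, methyl, methoxy or an amine would read at this carbon. As far as these compounds go, a longer chain there also remains open, so a single exchange cannot show a trend with chain length.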